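A few compounds are considered here, and "the series" means these few. Any claim that something is new, unique, unknown or untested is made for them only; others in the source may bear on it.

In a functional assay on HEL cells (Homo sapiens) (a lower number here means that less compound is tolerated, a higher number that more compound is tolerated), compound 1 (`Cc1cn([C@@H]2O[C@H](CO[Si](C)(C)C(C)(C)C)[C@@]3(OS(=O)(=O)C=C3NCC(N)=O)[C@H]2O[Si](C)(C)C(C)(C)C)c(=O)n(C)c1=O`) gives 13500 nM. Compound 2 (`Cc1cn([C@@H]2O[C@H](CO[Si](C)(C)C(C)(C)C)[C@@]3(OS(=O)(=O)C=C3NCC(=O)OCc3ccccc3)[C@H]2O[Si](C)(C)C(C)(C)C)c(=O)n(C)c1=O`) gives > 200000 nM, a limit and not a number, so it stands at the limit of > 200000 nM in this assay, at which 1 of the 2 values shown sits. Compound 3 (`CCNC(=O)NC1=CS(=O)(=O)O[C@@]12[C@@H](CO[Si](C)(C)C(C)(C)C)O[C@@H](n1cc(C)c(=O)n(C)c1=O)[C@@H]2O[Si](C)(C)C(C)(C)C`) differs from compound 2 at one place, on an amine nitrogen: ethylcarbamoyl in place of (benzyloxycarbonyl)methyl on an amine nitrogen. Within the data shown here, the only measured step bearing on this is large, an at least 14-fold higher number from compound 1 to compound 2 (1.17 log units; beyond the scatter), and it shows that a change in this side group alone can shift the number widely. Compound 3 no longer carries the benzyloxy group, so a lower number is expected, an estimated at least 4.0-fold lower number from compound 2 to compound 3 (0.60 log units; beyond the scatter). For compound 3 the expected value is 50000 nM, with an estimated range of 12000 nM to 200000 nM.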

Compound 3, half-maximal cytotoxic concentration: 10000 nM
Compound 3: middle estimate off by 5.0-fold (0.70 log units), on the high side; the whole stated range lies above it.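

In this assay, ethylcarbamoyl on the amine nitrogen gives an at least 20-fold lower number from compound 2 to compound 3 (1.30 log units; beyond the scatter). The value of compound 2 is a limit and not a number: the limit of > 200000 nM in this assay, at which 1 of the 3 values shown sits. Carbamoylmethyl and ethylcarbamoyl cannot be told apart, with a 1.4-fold lower number from compound 1 to compound 3 (0.13 log units; within the scatter), so among the three side groups shown, only the (benzyloxycarbonyl)methyl group of compound 2 stands apart.

From the compounds shown here alone, what a carboxylic acid or a methyl ester would give in place of the benzyl ester remains open. So does whether a plain benzyl group on the same nitrogen would match compound 2.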